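The source may report more compounds than this note shows. Statements on the series, on what has been measured and on what is new or still open speak of the compounds shown alone.

For the measured compounds named here, in an ADME assay on MDCK cells (Canis lupus familiaris) for cytotoxicity, read by MTT assay, with a stated time of 24 h (a lower number here means that less compound is tolerated, a higher number that more compound is tolerated), compound 3, `O=[N+]([O-])c1ccc(S(=O)(=O)NCc2ccsc2)cc1`, gives 139000 nM, the only true number among the three measured compounds. Compound 1, `O=[N+]([O-])c1ccc(S(=O)(=O)NCc2ccoc2)cc1`, gives > 236000 nM, which is a limit of the assay and not a number. Compound 2, `Cc1cc(CNS(=O)(=O)c2ccc([N+](=O)[O-])cc2)c(C)s1`, gives > 204000 nM, and this too is a limit.

The next compound, compound 4, `O=[N+]([O-])c1ccc(S(=O)(=O)NCc2cccs2)cc1`, has not yet been measured. It is an isomer of compound 3, with thiophen-2-yl in place of thiophen-3-yl on a saturated chain carbon bound to a sulfonamide nitrogen.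

Three measured steps change the group at this same place. The first is an at least 1.6-fold lower number from compound 1 to compound 3 (0.22 log units; that floor lies within the scatter), and the second is an at least 1.4-fold lower number from compound 2 to compound 3 (0.16 log units; that floor lies within the scatter). The third is a step that the two limits leave unreadable from compound 1 to compound 2. None of them is a swap between thiophen-3-yl and thiophen-2-yl, so they bear on the change only indirectly. Neither readable step shows a shift that is certain to lie beyond the scatter in this assay, so no clear direction can be drawn from them.

The step expected here, a 1.0-fold higher number from compound 3 to compound 4 (0.00 log units; within the scatter), is estimated to stay within the scatter. For compound 4 the expected value is 140000 nM. The estimated range runs from 75000 nM to 260000 nM.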

Compound 4, half-maximal cytotoxic concentration: 133000 nM
Estimate against measurement, compound 4: 1.1-fold (0.02 log units) above, and the stated range covers the measured number.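

In this assay, thiophen-2-yl in place of thiophen-3-yl on a saturated chain carbon bound to a sulfonamide nitrogen gives a 1.0-fold lower number from compound 3 to compound 4 (0.02 log units; within the scatter), so a direct swap between the two isomers can now be read, and it shows no change that this assay can separate. The other two new steps, an at least 1.5-fold lower number from compound 2 to compound 4 (0.18 log units; that floor lies within the scatter) and an at least 1.7-fold lower number from compound 1 to compound 4 (0.24 log units; that floor lies within the scatter), match what compound 3 showed earlier, so neither thiophene isomer is set clearly apart from the 2,5-dimethylthiophen-3-yl or the furan-3-yl compound. The step from compound 2 is only a floor because compound 2 stands at a limit and not at a number: the limit of > 204000 nM in this assay, at which 1 of the 4 values shown sits.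

How far compound 1 lies from the two thiophene isomers stays open, since its value is likewise a limit and not a number: the limit of > 236000 nM in this assay, at which 1 of the 4 values shown sits. Also open is whether a phenyl ring, a pyridine ring, an amine or a longer chain at this same place would move the number in this assay beyond the usual scatter, as no step shown here does so with certainty.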